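This account rests on a few compounds, and the source may have more. Where it says the series, first, only, none or still open, it means among the compounds named here.

Compound 1 `NS(=O)(=O)c1cccc(-c2nc(C(c3ccc(F)cc3)c3ccc(F)cc3)sc2CC(=O)O)c1` and compound 2 `COc1ccc(C(c2ccccn2)c2nc(-c3ccc(Cl)cc3)c(CC(=O)O)s2)cc1` have both been tested in an in vitro functional assay on HEK285-7 cells for antagonist activity at prostaglandin D2 receptor 2 (Homo sapiens), read by BRET and beta-arrestin recruitment; on this read-out higher numbers stand for larger maximal responses and lower numbers for smaller maximal responses. There compound 1 reaches 55%, the lower of the two numbers, while compound 2 reaches 80%, a gap beyond the usual scatter. Among the measured compounds shown here, compound 3 `N#Cc1cc(-c2nc(C(c3ccc(F)cc3)c3ccc(F)cc3)sc2CC(=O)O)ccc1F` is not yet measured and differs from compound 1 in one place: 3-cyano-4-fluorophenyl in place of 3-sulfamoylphenyl on an aromatic carbon No measured pair shows a change of this kind, so only a modest step in either direction, or none beyond the scatter, is expected in this assay. Compound 3 is estimated at 60%, with a likely range from 35% to 85%. The expected step is then a number 5 percentage points higher from compound 1 to compound 3 (within the scatter).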

Compound 3, largest response reached (reported as efficacy), in percent of the reference or control that the assay uses: 80%
Estimate against measurement, compound 3: 20 percentage points below; measured number inside the range.
By their numbers in this assay, from the lowest: compound 1; then compounds 2 and 3 (each within the scatter of the next).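

On the aromatic carbon next to the ring nitrogen, placing 3-cyano-4-fluorophenyl in place of 3-sulfamoylphenyl gives in this assay a number 25 percentage points higher from compound 1 to compound 3 (beyond the scatter). Among the compounds shown here, this is the first measured sign that the aryl group at this position can shift the maximal response while the rest of compound 1 stays the same. Nothing measured here explains the step. As far as these compounds go, the swap changes several features at once, so the separate roles of the nitrile, the fluorine and the loss of the sulfamoyl group remain open. From the compounds shown here alone, how a 3-aminophenyl group would read at this carbon is also open.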